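This account rests on a few compounds, and the source may have more. Where it says the series, first, only, none or still open, it means among the compounds named here.

In an ADME assay on L02 cells (Homo sapiens) for cytotoxicity, read by MTT assay, with a stated time of 48 h (on this read-out higher numbers stand for weaker inhibition and lower numbers for stronger inhibition), compound 1 `CCn1c(C(=O)NCCN)ccc1C(CC)(CC)c1ccc(OCC(O)C(C)(C)C)c(C)c1` gives 2400 nM and compound 2 `C=CCN(C)C(=O)c1ccc(C(CC)(CC)c2ccc(OCC(O)C(C)(C)C)c(C)c2)n1CC` gives 6300 nM. Compound 3 `CC[C@@H](C)[C@H](NC(=O)c1ccc(C(CC)(CC)c2ccc(OCC(=O)C(C)(C)C)c(C)c2)n1CC)C(=O)O` gives 1500 nM, which is within the scatter of the value for compound 1 and lower than the value for compound 2.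

Compound 4 `CC[C@@H](C)[C@H](NC(=O)c1ccc(C(CC)(CC)c2ccc(OCC(O)C(C)(C)C)c(C)c2)n1CC)C(=O)O` differs from compound 3 in one place: 1-hydroxy-2,2-dimethylpropyl in place of (tert-butyl)carbonyl on a saturated chain carbon bound to an oxygen on an aromatic ring. Thus ((tert-butyl)carbonyl)methoxy becomes 2-hydroxy-3,3-dimethylbutoxy, the group already carried by compound 1 and compound 2.

Within the data shown here, no measured pair isolates this change. Among the measured compounds shown here, the only measured step is a 2.6-fold higher number from compound 1 to compound 2 (0.42 log units; beyond the scatter), and it concerns a group on a carbonyl carbon, not this group, so it bears only indirectly. It does show that the numbers for compounds carrying 2-hydroxy-3,3-dimethylbutoxy can move with the group on that carbonyl carbon. With compound 1 at 2400 nM as the closest guide, a slight upward drift is expected in this assay, but no step beyond the scatter. The expected change is a 1.7-fold higher number from compound 3 to compound 4 (0.22 log units; within the scatter). For compound 4 the estimated value is 2500 nM, with an expected range from 1000 nM to 7000 nM.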

Compound 4, half-maximal inhibitory concentration: 1400 nM
Estimate against measurement, compound 4: 1.8-fold (0.25 log units) above; low and high end bracket the measured number.
By their numbers in this assay, from the lowest: compounds 4, 3 and 1 (each within the scatter of the next); then compound 2.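

In this assay, the change at this position can now be read directly: a 1.1-fold lower number from compound 3 to compound 4 (0.03 log units; within the scatter), so 2-hydroxy-3,3-dimethylbutoxy and ((tert-butyl)carbonyl)methoxy are not separated here when 1-carboxy-2-methylbutyl sits on the amide-type nitrogen. With 2-hydroxy-3,3-dimethylbutoxy held constant, the group on the carbonyl carbon can matter, but not in every swap: a 4.5-fold lower number from compound 2 to compound 4 (0.65 log units; beyond the scatter) lies beyond the scatter, whereas a 1.7-fold lower number from compound 1 to compound 4 (0.23 log units; within the scatter) lies within it. No measurement offered here accounts for any of these steps.

Still open, as far as these compounds go, is whether the swap at this position stays as small when the carbonyl carbon carries allyl(methyl)amino or (2-aminoethyl)amino. Also open, from the compounds shown here alone, is whether an amine in place of the hydroxy, or a longer chain in place of 2-hydroxy-3,3-dimethylbutoxy, would give a step beyond the scatter.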